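A few compounds are considered here, and "the series" means these few. Any claim that something is new, unique, unknown or untested is made for them only; others in the source may bear on it.

Three esters built on the same crown-type core have been tested in a functional assay on WiDr cells (Homo sapiens) for inhibition, read by sulforhodamine B assay, with a stated time of 48 h (a higher number here means a weaker inhibitor of growth, a lower number a stronger inhibitor of growth), and none has returned a number. Compound 1 `O=C(/C=C/c1ccccc1)OCC1COCCOCCOCCOCCOCCO1` gives only the limit > 100000 nM in this assay. Compound 2 `O=C(CCCCCc1ccccc1)OCC1COCCOCCOCCOCCOCCO1` likewise gives the limit > 100000 nM in this assay. Compound 3 `CC/C=C/CC(=O)OCC1COCCOCCOCCOCCOCCO1` also stands at the limit > 100000 nM in this assay, so its position is known only as a limit, not as a value. The steps among them, a step that the two limits leave unreadable from compound 1 to compound 2, a step that the two limits leave unreadable from compound 1 to compound 3 and a step that the two limits leave unreadable from compound 2 to compound 3, are therefore unreadable in size, since the limit of > 100000 nM in this assay, at which 3 of the 3 values shown sit, covers all of them. Compound 4 `O=C(CCCCOc1ccccc1)OCC1COCCOCCOCCOCCOCCO1` differs from compound 3 in that (3-phenoxypropyl in place of but-1-en-1-yl on a saturated chain carbon bound to a carbonyl carbon). Among the measured compounds shown here, none of the measured steps is readable, so no direction can be taken from them; the only guide is that every change so far has left the compounds at the limit. The step from compound 3 to compound 4 is expected to be a step that the limit leaves unreadable from compound 3 to compound 4. Compound 4 is therefore expected to give about 150000 nM in this assay, within 40000 nM to 600000 nM, most probably again reported only as a limit.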

Compound 4, concentration for 50% growth inhibition: > 100000 nM
Compound 4: only a limit was reported (the forecaster's own chance of this, stated with the estimate: 85%); the middle value does not contradict the limit.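

Compound 4 gives only a limit, so its steps to compound 1, compound 2 and compound 3 cannot be read in size: the limit of > 100000 nM in this assay, at which 4 of the 4 values shown sit.

The compounds shown leave open which group on the carbonyl carbon, if any, would return an actual value in this assay.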